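The source may hold more compounds than are shown below. What is called first, only, known or untested is meant among the compounds shown, and "the series" means these compounds.

In an ADME assay on a cell-free system (plasma, Homo sapiens) for metabolic stability, at 37 degrees C (on this read-out higher numbers stand for a longer-lived compound and lower numbers for a shorter-lived compound), compound 2 `CCC/N=C1\S/C(=C\c2ccc(C(=O)NCC(=O)N(C)C)cc2)C(=O)N1c1ccccc1O` gives > 3 h, which is a limit and not a number. Compound 1 `CCC/N=C1\S/C(=C\c2ccc(C(=O)OC)c(Cl)c2)C(=O)N1c1ccccc1C` gives > 3 h, also a limit. Compound 3 `CCC/N=C1\S/C(=C\c2ccc(C(=O)OCC(O)CO)cc2)C(=O)N1c1ccccc1O` gives > 3 h, again a limit. Compound 4 `CCC/N=C1\S/C(=C\c2ccc(CCC(=O)OC)cc2)C(=O)N1c1ccccc1O` differs from compound 2 as follows: 2-(methoxycarbonyl)ethyl in place of ((dimethylcarbamoyl)methyl)carbamoyl on an aromatic carbon. In words, 2-(methoxycarbonyl)ethyl stands in place of ((dimethylcarbamoyl)methyl)carbamoyl on an aromatic carbon. Among the compounds with values here, the one measured step at this place is a step that the two limits leave unreadable from compound 2 to compound 3, so it offers no size to carry over. The whole record is the limit of > 3 h in this assay, at which 3 of the 3 values shown sit. With no readable step to guide it, the expectation in this assay is for no change beyond the scatter, and the expected step is a number no higher from compound 2 to compound 4 (the limit leaves the size open). Compound 4 is estimated at 3 h, with an expected range from 1 h to 6 h.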

Compound 4, half-life in the Homo sapiens assay: > 3 h
Compound 4 ended at the assay's limit; the forecaster's own chance of this, stated with the estimate: 55%; the middle value lies on the limit itself.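

In the Homo sapiens assay compound 4 gives > 3 h, which is a limit and not a number.

In the Homo sapiens assay, no step can be read from compound 2 or compound 3 to compound 4, since each result is a limit and not a number: the limit of > 3 h in the Homo sapiens assay, at which 4 of the 4 values shown sit.

In a physicochemical assay for lipophilicity, read by HPLC, measured as chromatographic lipophilicity (a lower number here means a more polar compound, a higher number a more lipophilic compound), compound 2 gives 1.9 and compound 4 gives 3.5.

The compounds shown leave open how long each one actually lasts, and whether any of these changes alters that.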